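The compounds below may be only part of what the source reports. "The series", "measured", "known", "first", "only" and "open" are said of these compounds alone.

Measured in a functional assay on CHO-K1 cells for agonist activity at Glucose-dependent insulinotropic receptor (Homo sapiens), read by a luciferase reporter, with a stated time of 5 h; a lower number here means that less compound is needed, a higher number that more compound is needed for the effect:
compound 1 `CC(C)OC(=O)N1CCC(Oc2ncnc3c2CCN3c2ccc(-c3nccs3)cc2F)CC1` gives 79.4 nM
compound 2 `CC(C)(C)OC(=O)N1CCC(Oc2ncnc3c2CCN3c2ccc(S(C)(=O)=O)cc2F)CC1` gives 20 nM
compound 3 `CCOC(=O)N1CCC(Oc2ncnc3c2CCN3c2ccc(S(C)(=O)=O)cc2F)CC1` gives 251 nM

Compound 3 holds the highest number of the three in this assay; compound 1 stands nearest to it, compound 2 furthest. Compound 4 `CCCCOC(=O)N1CCC(Oc2ncnc3c2CCN3c2ccc(S(C)(=O)=O)cc2F)CC1` differs from compound 3 by ethyl in place of hydrogen on a saturated chain carbon, two bonds along the chain from an oxygen next to a carbonyl group. Among the measured compounds shown here, only one measured step touches this part of the molecule: a 13-fold higher number from compound 2 to compound 3 (1.10 log units; beyond the scatter). Compound 1 carries a branched group on the same oxygen but differs elsewhere as well, so its value can only be read as lying between those of compound 2 and compound 3. A longer, unbranched chain on that oxygen is therefore expected to move the number downward, by a step of a 4.0-fold lower number from compound 3 to compound 4 (0.60 log units; beyond the scatter), though less surely than branching did. Compound 4 is estimated at 63 nM, within 20 nM to 200 nM.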

Compound 4, half-maximal effective concentration: 50.1 nM
For compound 4 the middle estimate is 1.3-fold (0.10 log units) above the measured one, within the range that was stated.
By their numbers in this assay, from the lowest: compound 2; then compounds 4 and 1 (each within the scatter of the next); then compound 3.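

In this assay, an unbranched chain on this oxygen also moves the number: ethyl to butyl gives a 5.0-fold lower number from compound 3 to compound 4 (0.70 log units; beyond the scatter), so branching is not required for a gain over ethyl. Branching still matters here, as butyl in place of tert-butyl gives a 2.5-fold higher number from compound 2 to compound 4 (0.40 log units; beyond the scatter). No available evidence bears on the reason for either step.

Going by these compounds, whether a longer chain such as hexyl continues the downward trend remains open. So does whether a cyclopropyl or benzyl group on that oxygen would match tert-butyl.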